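Working notes on compound 4 from compound 2

A few compounds are considered here, and "the series" means these few. Any claim that something is new, unique, unknown or untested is made for them only; others in the source may bear on it.

compound 1 `COc1cc(-c2nn(-c3cccc(NC(=O)Nc4ccc(Cl)c(Cl)c4)c3)cc2-c2ccncc2)ccc1Cl` — a limit only in a functional assay on CAKI-1 cells (Homo sapiens) for inhibition, read by sulforhodamine B assay, with a stated time of 48 h; a lower number here means that less compound is tolerated, a higher number that more compound is tolerated: > 50000 nM
compound 2 `O=C(Nc1cccc(-n2cc(-c3ccncc3)c(-c3ccc(Cl)c(O)c3)n2)c1)Nc1ccc(Cl)c(Cl)c1` — a limit only in this assay: > 32500 nM
compound 3 `COc1cc(-c2nn(-c3cccc(NC(=O)c4ccccc4)c3)cc2-c2ccncc2)ccc1Cl` — a limit only in this assay: > 100000 nM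

Compound 2 stands as one limit among three limits; no number separates it from compound 1 or compound 3. Compound 4 `O=C(Nc1cccc(-n2cc(-c3ccncc3)c(-c3ccc(Cl)c(O)c3)n2)c1)Nc1ccc(Cl)c(C(F)(F)F)c1` carries trifluoromethyl in place of chloro on an aromatic carbon. Within the data shown here, no measured step makes this same change. The two measured steps, a step that the two limits leave unreadable from compound 1 to compound 2 and a step that the two limits leave unreadable from compound 1 to compound 3, both start from compound 1 and remain unreadable between limits; neither bears directly on the swap of chloro for trifluoromethyl. With all three known values at limits, compound 4 in this assay is expected to show a step that the limit leaves unreadable from compound 2 to compound 4, that is nothing readable beyond the scatter. Compound 4 is estimated at 50000 nM, with a range from 20000 nM to 150000 nM, most probably again reported as a limit.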

Compound 4, concentration lethal to 50% of the cells: > 32500 nM
Compound 4: only a limit was reported (the forecaster's own chance of this, stated with the estimate: 80%); the middle value does not contradict the limit.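

Compound 2 stands at > 32500 nM in this assay, a limit. Among these compounds, compound 4 stands at > 32500 nM, again a limit, and no step to it from compound 2 can be read. Left open is whether trifluoromethyl in place of chloro changes the read-out at all: every compound shown gives only a limit.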